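The source may hold more compounds than are shown below. What is called first, only, known or untested is meant among the compounds shown, and "the series" means these compounds.

Two compounds share one core and differ only in the halogen on one of the two benzylidene arms. In a functional assay on MCF7 cells (Homo sapiens) for cytotoxicity, read by CCK-8 assay, with a stated time of 72 h (on this read-out lower numbers stand for stronger inhibition and higher numbers for weaker inhibition), compound 1 `C=CCn1c(=O)/c(=C\c2cccc(Cl)c2)[nH]c(=O)/c1=C\c1ccccc1OC` gives 5200 nM. Among the compounds with values here, compound 2 `C=CCn1c(=O)/c(=C\c2cccc(F)c2)[nH]c(=O)/c1=C\c1ccccc1OC` gives 13700 nM, the higher of the two numbers, and the only step on record is a 2.6-fold higher number from compound 1 to compound 2 (0.42 log units; beyond the scatter), which came with the change from chloro to fluoro on an aromatic carbon. Compound 3 `C=CCn1c(=O)/c(=C\c2cccc(Cl)c2Cl)[nH]c(=O)/c1=C\c1ccccc1OC` carries 2,3-dichlorophenyl in place of 3-fluorophenyl on a double-bonded chain carbon bound to an aromatic carbon. This change puts chloro back where compound 2 carries fluoro and adds a second chloro. Within the data shown here, the step from compound 1 to compound 2 is the only guide; reversing it points to a lower number, and the second chloro has no precedent here. For compound 3 the expected step is therefore a 3.0-fold lower number from compound 2 to compound 3 (0.48 log units; beyond the scatter). Compound 3 is estimated at 4500 nM, with a range from 1500 nM to 14000 nM.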

Compound 3, half-maximal inhibitory concentration: 2100 nM
Beside the measured number, compound 3's estimate is 2.1-fold (0.33 log units) above it; low and high end bracket the measured number.
By their numbers in this assay, from the lowest: compound 3; then compound 1; then compound 2.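

Adding a second chloro to the aromatic ring of compound 1 gives a 2.5-fold lower number from compound 1 to compound 3 (0.39 log units; beyond the scatter) in this assay, so this ring still responds to further substitution after the first chloro. Within the data shown here, the full change from 3-fluorophenyl to 2,3-dichlorophenyl gives a 6.5-fold lower number from compound 2 to compound 3 (0.81 log units; beyond the scatter) and, across these three compounds, the number falls as the arm goes from fluoro to one chloro to two, with no compound going against that order. Nothing available explains why the added chloro lowers the number.

Still open, as far as these compounds go, is whether the lower number depends on chlorine itself, or whether a methyl group, an amine or a carboxylic acid on this ring would shift it in the same direction. The compounds shown also leave open whether a second chloro elsewhere on the ring would match 2,3-dichlorophenyl.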